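Nitro to dimethylamino swap on two enone cores

The compounds below may be only part of what the source reports. "The series", "measured", "known", "first", "only" and "open" are said of these compounds alone.

Compound 1 `CC(=O)/C(C)=C/c1ccc([N+](=O)[O-])cc1` and compound 2 `CC(=O)/C(C)=C/c1ccc(N(C)C)cc1` share one core and differ only by dimethylamino in place of nitro on an aromatic carbon. In an ADME assay on LLC-MK2 cells (Macaca mulatta) for cytotoxicity, read by MTT assay, with a stated time of 48 h (a lower number here means that less compound is tolerated, a higher number that more compound is tolerated), compound 1 gives 266000 nM. In this assay compound 2 gives 150000 nM. The resulting step is a 1.8-fold lower number from compound 1 to compound 2 (0.25 log units; within the scatter), so the two values cannot be told apart here.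

Compound 3 `C/C(=C\c1ccc([N+](=O)[O-])cc1)C(=O)/C=C/c1ccc([N+](=O)[O-])cc1` has a larger core; the difference between the core of compound 1 and the core of compound 3 is not broken down here. In this assay compound 3 gives 32500 nM, the lowest of the three numbers, and its gaps to compound 2 and to compound 1 both lie beyond the scatter, so compound 3 is the least tolerated of the measured set.

Compound 4 `C/C(=C\c1ccc([N+](=O)[O-])cc1)C(=O)/C=C/c1ccc(N(C)C)cc1` is not yet measured. It differs from compound 3 by dimethylamino in place of nitro on an aromatic carbon. Among the compounds with values here, this is the same kind of change as the one from compound 1 to compound 2, with the surroundings described differently: in compound 1 the place is para to a group of 6 heavy atoms, in compound 3 it is para to a large group.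

The step of a 1.6-fold lower number from compound 3 to compound 4 (0.21 log units; within the scatter) is expected to stay small because a 1.8-fold lower number from compound 1 to compound 2 (0.25 log units; within the scatter) was itself within the scatter. For compound 4 in this assay the estimate is 20000 nM, with a likely range from 8000 nM to 60000 nM.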

Compound 4, half-maximal cytotoxic concentration: 25900 nM
Compound 4: the middle estimate sits 1.3-fold (0.11 log units) below what was measured; low and high end bracket the measured number.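

In this assay the new step is a 1.3-fold lower number from compound 3 to compound 4 (0.10 log units; within the scatter), so dimethylamino in place of nitro on an aromatic carbon gives no readable difference on the larger core, as was already the case on the smaller one. Set side by side, the two steps cannot be told apart, and in this series the change carries from one core to the other without a visible shift: the same change on two cores in this assay, a 1.8-fold lower number (0.25 log units; within the scatter) from compound 1 to compound 2 and a 1.3-fold lower number (0.10 log units; within the scatter) from compound 3 to compound 4, 1.4-fold (0.15 log units) apart, within the scatter of two such steps This shows only that the swap stays within the scatter on these two cores in this one cell assay; it does not show that the two groups are interchangeable in general, it gives no direction for the change, and it says nothing about any other read-out.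

Compound 4 still carries one nitro group, so the compounds shown leave open whether replacing that remaining group with dimethylamino would also stay within the scatter. They also leave open whether a different group at the same place, such as a primary amine, a methoxy group or a carboxylic acid, would behave as nitro and dimethylamino do on either core.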